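The source may report more compounds than this note shows. Statements on the series, on what has been measured and on what is new or still open speak of the compounds shown alone.

Measured in a functional assay on HT-29 cells (Homo sapiens) for inhibition, read by MTT assay, with a stated time of 48 h; on this read-out higher numbers stand for weaker inhibition and lower numbers for stronger inhibition:
- Compound 1 `O=C1N/C(=N\Cc2ccccc2)S/C1=C1/CCNC(=O)c2[nH]ccc21`: 36500 nM
- Compound 2 `O=C1N/C(=N\Cc2ccc(Cl)cc2)S/C1=C1/CCNC(=O)c2[nH]ccc21`: > 100000 nM (a limit, not a number)

Compound 1, with no substituent on the benzyl ring, gives a true number, whereas compound 2 gives none. On the numbers shown, compound 2 stands at the limit of > 100000 nM in this assay, at which 1 of the 2 values shown sits.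

Compound 3 `CC(C)(C)c1ccc(C/N=C2\NC(=O)/C(=C3\CCNC(=O)c4[nH]ccc43)S2)cc1` carries tert-butyl in place of chloro on an aromatic carbon, para to a large group (tert-butyl in place of chloro on an aromatic carbon). For the measured compounds named here, the only measured step that bears on this change is an at least 2.7-fold higher number from compound 1 to compound 2 (0.43 log units; beyond the scatter). That single step points upward and is modest at its stated minimum, so, resting on it alone, no step beyond the scatter is expected in this assay, and the number is expected to stay high. The expected outcome is a number no higher from compound 2 to compound 3 (the limit leaves the size open). For compound 3 the estimate is 100000 nM, with an expected range from 30000 nM to 300000 nM.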

Compound 3, half-maximal inhibitory concentration: 43400 nM
Compound 3: middle estimate off by 2.3-fold (0.36 log units), on the high side; measured number inside the range.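

In this assay, replacing chloro with tert-butyl on this aromatic carbon, para to a large group, gives an at least 2.3-fold lower number from compound 2 to compound 3 (0.36 log units; beyond the scatter), so the rise seen with chloro does not hold for every group placed there. Against hydrogen at the same carbon, tert-butyl gives a 1.2-fold higher number from compound 1 to compound 3 (0.08 log units; within the scatter), so the two cannot be told apart on this read-out, even though tert-butyl brings 4 heavy atoms. Compound 2 remains a limit and not a number, which leaves the full size of its step open: the limit of > 100000 nM in this assay, at which 1 of the 3 values shown sits.

As far as these compounds go, how an amine, a methoxy group or a carboxylic acid on this carbon would read remains open. The compounds shown also cannot say why chloro stands apart from both hydrogen and tert-butyl, or whether this holds on other carbons of the ring.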